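The compounds below may be only part of what the source reports. "The series", "measured", "known", "first", "only" and "open" are said of these compounds alone.

Working notes on the series. Among the compounds with values here, compound 1 `O=C(/C=C/c1ccccc1)NS(=O)(=O)c1ccc(F)cc1` gives 2.1 ug/mL in a functional assay on B16-F10 cells (Mus musculus) for antiproliferative activity, read by ELISA and MTT assay, with a stated time of 48 h (on this read-out lower numbers stand for stronger inhibition and higher numbers for weaker inhibition), the highest of the two numbers so far; its nearest neighbour is compound 2 `O=C(/C=C/c1ccc(F)cc1)NS(=O)(=O)c1ccc(F)cc1`, which gives 0.8 ug/mL. Within the data shown here, the one measured step, a 2.6-fold lower number from compound 1 to compound 2 (0.42 log units; beyond the scatter), came from fluoro in place of hydrogen on an aromatic carbon. Compound 3 `O=C(/C=C/c1ccccc1[N+](=O)[O-])NS(=O)(=O)c1ccc(F)cc1` differs from compound 1 by nitro in place of hydrogen on an aromatic carbon, a different group placed ortho to a large group, so the measured step bears on it only loosely. A small lowering of the number or no step beyond the scatter is expected, with a 1.4-fold lower number from compound 1 to compound 3 (0.15 log units; within the scatter) as the estimated step. For compound 3 the expected value is 1.5 ug/mL, within 0.6 ug/mL to 4 ug/mL.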

Compound 3, half-maximal inhibitory concentration: 6 ug/mL
The estimate for compound 3 lay 4.0-fold (0.60 log units) below the measured number; measured number above the stated range.
By their numbers in this assay, from the lowest: compound 2; then compound 1; then compound 3.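

In this assay, nitro ortho to a large group moves the number the opposite way from the fluoro step: a 2.9-fold higher number from compound 1 to compound 3 (0.46 log units; beyond the scatter), against a 2.6-fold lower number from compound 1 to compound 2 (0.42 log units; beyond the scatter). A substituent on this aromatic ring therefore does not lower the number in every case, and the two steps cannot separate the effect of the group from that of its place. No available evidence accounts for the higher number.

Still open, as far as these compounds go, is whether fluoro ortho to a large group would lower the number or raise it. An amine or a methoxy group at that same place is equally unresolved.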